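Series notes: carboxy replaced by methoxy on the aryl ether

The compounds below may be only part of what the source reports. "The series", "measured", "known", "first", "only" and "open" are said of these compounds alone.

Measured so far:
compound 1 `Cc1ccc(OCCCCOc2ccc(C(=O)CC(C)(C)C)c(O)c2C)cc1C(=O)O`, 309 nM
compound 2 `Cc1c(OCCCCOc2ccc(C(=O)O)cc2F)ccc(C(=O)CC(C)(C)C)c1O`, 1230 nM

In an assay for positive allosteric modulation of metabotropic glutamate receptor 3 (Rattus norvegicus) (a higher number here means that more compound is needed for the effect, a lower number that less compound is needed), compound 2 has the highest of the two numbers; its nearest neighbour is compound 1, and the step of a 4.0-fold higher number from compound 1 to compound 2 (0.60 log units; beyond the scatter) places compound 2 at the weaker end of the pair. Compound 3 `COc1ccc(OCCCCOc2ccc(C(=O)CC(C)(C)C)c(O)c2C)cc1` is not yet measured. It differs from compound 2 by 4-methoxyphenyl in place of 4-carboxy-2-fluorophenyl on an oxygen on a saturated carbon. For the measured compounds named here, the only measured step that bears on this position is a 4.0-fold higher number from compound 1 to compound 2 (0.60 log units; beyond the scatter), in which the aryl group on that oxygen was changed while a carboxy group was kept. Compound 3 gives up the carboxy group entirely, a larger change than that step, so a further increase in this assay is expected rather than no change beyond the scatter. Compound 3 is expected at 3500 nM, within the range 900 nM to 14000 nM. For compound 3 this expectation corresponds to a 2.8-fold higher number from compound 2 to compound 3 (0.45 log units; beyond the scatter).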

Compound 3, half-maximal effective concentration: "not active" (no number reported)
Nothing numeric was reported for compound 3, so the estimate cannot be set against anything.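

In this assay, for the compounds shown here, compound 3 is reported as not active with no number, so no step from compound 2 to compound 3 can be read. The compounds shown leave open whether a carboxy group on the aryl ether is needed for a measurable number. Nothing here accounts for this result.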